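The source may hold more compounds than are shown below. What is called first, only, known or untested is meant among the compounds shown, and "the series" means these compounds.

Measured compounds in an assay on isolated protein for inhibition of Amine oxidase [flavin-containing] A (Rattus norvegicus); on this read-out higher numbers stand for weaker inhibition and lower numbers for stronger inhibition:
- compound 1 `C#CCNCc1cc2ccccc2n1C`, this assay 240 nM
- compound 2 `C#CCN(C)Cc1cc2cc(O)ccc2n1C`, this assay 4 nM

Compound 2 stands at the lowest of the two numbers recorded. Its nearest neighbour on this read-out is compound 1, whose number is higher by a margin that lies beyond the usual scatter of repeated measurements, so compound 2 is the stronger inhibitor of the pair. Compound 1 and compound 2 differ in more than one place, so no single structural step accounts for that gap.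

Compound 3 `C#CCN(C)Cc1cc2ccccc2n1C` has not yet been measured. Relative to compound 2 the change is hydrogen in place of hydroxy on an aromatic carbon. Compound 3 thus carries the same methylated amine as compound 2 and the same unsubstituted six-membered ring as compound 1. For the measured compounds named here, no step between measured compounds isolates this change, so the expected size rests on the position of compound 2 at 4 nM and the gap up to compound 1; the number for compound 3 is expected to move upward, by the step of a 7.5-fold higher number from compound 2 to compound 3 (0.88 log units; beyond the scatter), beyond the scatter. The estimate for compound 3 in this assay is 30 nM, within the range 8 nM to 120 nM.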

Compound 3, inhibition constant: 0.3 nM
The estimate for compound 3 lay 100-fold (2.00 log units) above the measured number; measured number outside the range, below it.
By their numbers in this assay, from the lowest: compound 3; then compound 2; then compound 1.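

In this assay, hydrogen in place of hydroxy on the aromatic carbon meta to a fused ring and para to a fused ring gives a 13-fold lower number from compound 2 to compound 3 (1.12 log units; beyond the scatter), so the low number of compound 2 does not depend on the hydroxy, and at this position the hydroxy goes with weaker inhibition than hydrogen. The methyl on the amine nitrogen now has a step of its own, an 800-fold lower number from compound 1 to compound 3 (2.90 log units; beyond the scatter), which is beyond the scatter and shows that this single change goes with a large gain in inhibition on the unsubstituted core. Nothing available explains the size of either step, and no supporting data bear on the result.

Open, from the compounds shown here alone, is whether the loss seen with hydroxy extends to a methoxy or a fluorine on the same aromatic carbon, or whether it is particular to hydroxy. Also open, going by these compounds, is whether an ethyl or a longer chain on the amine nitrogen keeps the gain seen with methyl, since each change here rests on a single pair of compounds.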